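This account rests on a few compounds, and the source may have more. Where it says the series, first, only, none or still open, it means among the compounds named here.

Working notes on the series, all read in a physicochemical assay for solubility, measured as kinetic solubility, with a stated time of 1 h, at pH 7.4; on this read-out lower numbers stand for lower solubility and higher numbers for higher solubility. Compound 1 `CC(=O)Nc1nc(-c2ccc(F)c(Cl)c2)cs1` gives 10000 nM, compound 2 `NC1=NN(c2ccc(Cl)c(Cl)c2)CC1` gives 69000 nM, and compound 3 `N#CCC(=O)NC1=NN(c2ccc(Cl)c(Cl)c2)CC1` gives 202000 nM. That last number is the highest of the three, with compound 2 nearest and compound 1 furthest.

The unmeasured compound 4 `O=C(NC1=NN(c2ccc(Cl)c(Cl)c2)CC1)c1cccnc1` keeps the carbonyl and carries pyridin-3-yl in place of cyanomethyl on a carbonyl carbon.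

Going by the values given here, one measured step bears on this, and only indirectly: a 2.9-fold higher number from compound 2 to compound 3 (0.47 log units; beyond the scatter), a modest change on adding (cyanomethyl)carbonyl in place of hydrogen on an amine nitrogen. Among the compounds with values here, no measured pair changes the group on the carbonyl. With compound 3 at the top of the measured numbers at 202000 nM, a fall of similar size, beyond the scatter, is the working expectation in this assay, held with wide uncertainty.

The expected move is a 2.9-fold lower number from compound 3 to compound 4 (0.46 log units; beyond the scatter). Compound 4 is estimated at 70000 nM, with an expected range of 20000 nM to 200000 nM.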

Compound 4, solubility: 4000 nM
Compound 4: middle estimate off by 18-fold (1.24 log units), on the high side; measured number outside the range, below it.
By their numbers in this assay, from the lowest: compound 4; then compound 1; then compound 2; then compound 3.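

In this assay the group on the carbonyl carbon carries a large effect: there is a 51-fold lower number from compound 3 to compound 4 (1.70 log units; beyond the scatter), with pyridin-3-yl in place of cyanomethyl, and this step is larger than a 2.9-fold higher number from compound 2 to compound 3 (0.47 log units; beyond the scatter), seen on adding (cyanomethyl)carbonyl to the amine nitrogen. The rise seen with that addition therefore does not extend to every group on the carbonyl, since compound 2 gives 69000 nM and compound 4 gives 4000 nM. Nothing available gives a cause for the fall in compound 4.

As far as these compounds go, it remains open whether the fall follows the aromatic ring or its nitrogen, and how a phenyl ring, a morpholine or a short alkyl chain on the same carbonyl carbon would read. Also open, from the compounds shown here alone, is whether any group other than cyanomethyl holds the number near that of compound 3 at 202000 nM.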